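Shortening the chain of compound 3

The source may hold more compounds than are shown below. What is called first, only, known or untested is meant among the compounds shown, and "the series" means these compounds.

compound 1 `CCCCCCS(=O)(=O)c1ccc(O)c(C(=O)Nc2ccc(Br)cc2)c1`: 3.2
compound 2 `CCCCCCCCS(=O)(=O)c1ccc(O)c(C(=O)Nc2ccc(C(F)(F)F)cc2)c1`: 5.26
compound 3 `CCCCCCCCCCCCS(=O)(=O)c1ccc(O)c(C(=O)Nc2ccc(C(F)(F)F)cc2)c1`: 6.2

Compound 3 stands highest of the three in a physicochemical assay for lipophilicity (a lower number here means a more polar compound, a higher number a more lipophilic compound), beyond the scatter above both other compounds. Compound 4 `CCCCCCS(=O)(=O)c1ccc(O)c(C(=O)Nc2ccc(C(F)(F)F)cc2)c1` has not been measured. Its difference from compound 3 is hydrogen in place of hexyl on a saturated chain carbon, six bonds along the chain from a sulfonyl sulfur.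

Among the measured compounds shown here, the one measured step of this kind is a number 0.94 log units higher from compound 2 to compound 3 (beyond the scatter), where butyl enters on a saturated chain carbon. The present change runs the opposite way and removes the larger hexyl, so a fall greater than that step is expected in this assay, well beyond the scatter. Compound 1, at 3.2, carries the same hexyl chain as compound 4 but has bromine where compound 4 has trifluoromethyl, which widens the expectation downward. The expected change is a number 1.70 log units lower from compound 3 to compound 4 (beyond the scatter). Compound 4 is estimated at 4.5, with an expected range of 3.7 to 5.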

Compound 4, distribution coefficient: 4.18
Beside the measured number, compound 4's estimate is 0.32 log units above it; measured number inside the range.
By their numbers in this assay, from the lowest: compound 1; then compound 4; then compound 2; then compound 3.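

In this assay, with trifluoromethyl held constant, shortening dodecyl to hexyl gives a number 2.02 log units lower from compound 3 to compound 4 (beyond the scatter) and shortening octyl to hexyl gives a number 1.08 log units lower from compound 2 to compound 4 (beyond the scatter); the number therefore follows chain length across these three compounds, and the ethyl difference is about as large as the butyl difference seen in a number 0.94 log units higher from compound 2 to compound 3 (beyond the scatter). The chain is not the only place that moves this number: with hexyl held constant, trifluoromethyl in place of bromo on an aromatic carbon gives a number 0.98 log units higher from compound 1 to compound 4 (beyond the scatter), a step of about the same size as the ethyl difference. Nothing available here accounts for these steps.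

The compounds shown leave open whether a chain shorter than hexyl, such as butyl, would continue the same trend. They also leave open how a nitrile in place of trifluoromethyl, or an amine or carboxylic acid on the chain, would shift the number.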